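The source may hold more compounds than are shown below. What is called first, only, known or untested is meant among the compounds shown, and "the series" means these compounds.

- compound 1 `Cc1ccc(/C=C/C(=O)c2ccc(Nc3cc(C)nc4nc(SCc5nc6ccccc6[nH]5)nn34)cc2)cc1`: 1520 nM
- compound 2 `Cc1cc(Nc2ccc(C(=O)/C=C/c3ccc4ccccc4c3)cc2)n2nc(SC(=O)c3csc4ccc(Cl)cc34)nc2n1`: 35 nM
- compound 3 `Cc1cc(Nc2ccc(C(=O)/C=C/c3ccc4ccccc4c3)cc2)n2nc(SCC(=O)c3ccccc3)nc2n1`: 190 nM

In a functional assay on SW-620 cells (Homo sapiens) for cytotoxicity, read by MTT assay, with stated times of 4 h and 72 h, tested at 2 uM (on this read-out lower numbers stand for stronger inhibition and higher numbers for weaker inhibition), compound 1 has the highest number of the three and is therefore the weakest. Its nearest neighbour, compound 3, is clearly lower, and compound 2 is lower still. Compound 4 `Cc1cc(Nc2ccc(C(=O)/C=C/c3ccc(Cl)cc3)cc2)n2nc(SCc3nc4ccccc4[nH]3)nc2n1` differs from compound 1 in one place: chloro in place of methyl on an aromatic carbon. In this way 4-methylphenyl becomes 4-chlorophenyl.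

Among the compounds with values here, only one measured step compares compounds that differ in a single place: a 5.4-fold higher number from compound 2 to compound 3 (0.73 log units; beyond the scatter). That change sits on a sulfur, not on the ring that changes here, and it swaps much larger groups, so it offers little guidance. Within the data shown here, no measured pair tests chloro against methyl, which leaves the direction open. A step beyond the scatter is therefore not expected, and the estimate is a 1.3-fold lower number from compound 1 to compound 4 (0.10 log units; within the scatter). For compound 4 the expected value is 1200 nM, with an estimated range from 400 nM to 3500 nM.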

Compound 4, half-maximal inhibitory concentration: 230 nM
Beside the measured number, compound 4's estimate is 5.2-fold (0.72 log units) above it, and the stated range ends above it.
By their numbers in this assay, from the lowest: compound 2; then compounds 3 and 4 (each within the scatter of the next); then compound 1.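

The earlier compounds shown here offered no pair that tested this end of the molecule, and in this assay the change from 4-methylphenyl to 4-chlorophenyl gives a 6.6-fold lower number from compound 1 to compound 4 (0.82 log units; beyond the scatter). This shows that the group on this aromatic carbon matters: exchanging a single heavy atom, with no ring, hydrogen-bond donor, hydrogen-bond acceptor or net charge entering or leaving, moves the number beyond the usual scatter. No measurement at hand gives a reason for this step.

The compounds shown leave open whether this step is special to chloro or would also appear with fluoro, bromo, methoxy, trifluoromethyl or a dimethylamino group at the same place. They also leave open whether the same change would give a step of similar size with a different group on the sulfur.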